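The compounds below may be only part of what the source reports. "The series", "measured", "known", "first", "only" and "open" are said of these compounds alone.

Working notes on the series. Compound 1 `COc1cc(C(=O)c2cn(-c3cccc(Br)c3)cc2-c2ccccc2)cc(OC)c1OC` gives 78 nM in a functional assay on MCF7 cells (Homo sapiens) for cytotoxicity, read by MTT assay, with a stated time of 96 h; on this read-out higher numbers stand for weaker inhibition and lower numbers for stronger inhibition. Compound 2 `COc1cc(C(=O)c2cn(-c3cccc([N+](=O)[O-])c3)cc2-c2ccccc2)cc(OC)c1OC` gives 550 nM. Compound 3 `COc1cc(C(=O)c2cn(-c3ccc(Br)cc3)cc2-c2ccccc2)cc(OC)c1OC` gives 20 nM, and compound 4 `COc1cc(C(=O)c2cn(-c3ccc([N+](=O)[O-])cc3)cc2-c2ccccc2)cc(OC)c1OC` is still to be measured.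

The change from compound 1 to compound 2 is nitro in place of bromo on an aromatic carbon and made a 7.1-fold higher number from compound 1 to compound 2 (0.85 log units; beyond the scatter). The two cores differ as 4-bromophenyl in place of 3-bromophenyl on an aromatic nitrogen, which gave a 3.9-fold lower number from compound 1 to compound 3 (0.59 log units; beyond the scatter). The change from compound 3 to compound 4 is nitro in place of bromo on an aromatic carbon; it is the same kind of change, but the place differs: meta to a large group in compound 1, para to a large group in compound 3.

For the measured compounds named here, from compound 3 to compound 4 a step of about a 6.0-fold higher number from compound 3 to compound 4 (0.78 log units; beyond the scatter) is expected, resting on the single earlier step of a 7.1-fold higher number from compound 1 to compound 2 (0.85 log units; beyond the scatter) and weakened by the different place. Compound 4 is thus estimated at 120 nM, between 45 nM and 320 nM.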

Compound 4, half-maximal inhibitory concentration: 4000 nM
For compound 4 the middle estimate is 33-fold (1.52 log units) below the measured one; the whole stated range lies below it.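

Nitro in place of bromo does not carry over as a fixed step from one core to the other in this assay: the same change on two cores in this assay, a 7.1-fold higher number (0.85 log units; beyond the scatter) from compound 1 to compound 2 and a 200-fold higher number (2.30 log units; beyond the scatter) from compound 3 to compound 4, 28-fold (1.45 log units) apart, beyond the scatter of two such steps. The new step is a 200-fold higher number from compound 3 to compound 4 (2.30 log units; beyond the scatter), and 4-nitrophenyl in place of 3-nitrophenyl gives a 7.3-fold higher number from compound 2 to compound 4 (0.86 log units; beyond the scatter), whereas 4-bromophenyl in place of 3-bromophenyl gives a 3.9-fold lower number from compound 1 to compound 3 (0.59 log units; beyond the scatter); 4-nitrophenyl in place of 3-bromophenyl joins both changes and gives a 51-fold higher number from compound 1 to compound 4 (1.71 log units; beyond the scatter). This rests on a single pair on each core and shows neither the reason for the gap nor how any other group would behave.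

Open, as far as these compounds go, is where an amine or a nitrile would fall on these two cores, and whether the two steps would again differ with such a group.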